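The source may hold more compounds than are shown below. What is called first, only, known or untested is meant among the compounds shown, and "the series" means these compounds.

Compound 2 `COc1ccc(CCCCCCC(=O)c2ncc(-c3ccccn3)o2)cc1` has the lowest number of the two measured compounds in an assay for inhibition of Fatty-acid amide hydrolase 1 (Rattus norvegicus) (a lower number here means a stronger inhibitor, a higher number a weaker inhibitor), where compound 2 gives 6.2 nM. Its nearest neighbour is compound 1 `O=C(CCCCCCc1ccccn1)c1ncc(-c2ccccn2)o1`, which in this assay gives 120 nM; the step of a 19-fold lower number from compound 1 to compound 2 (1.29 log units; beyond the scatter) shows how much the number fell when one aromatic ring at the end of the chain was exchanged for another. Compound 3 `CSc1ccccc1CCCCCCC(=O)c1ncc(-c2ccccn2)o1` has not yet been measured. It differs from compound 2 in one place: 2-(methylsulfanyl)phenyl in place of 4-methoxyphenyl on a saturated chain carbon, six bonds along the chain from a carbonyl carbon. For the measured compounds named here, the only measured step, a 19-fold lower number from compound 1 to compound 2 (1.29 log units; beyond the scatter), bears on this change in that it also replaced the ring at the end of the chain, but there a nitrogen-containing ring gave way to a carbon-only ring, whereas here one carbon-only ring carrying one hydrogen-bond acceptor replaces another of the same count. Going by the values given here, no measured pair compares a 4-methoxyphenyl ring with a 2-(methylsulfanyl)phenyl ring. The expected step in this assay is therefore modest, a 1.9-fold higher number from compound 2 to compound 3 (0.29 log units; within the scatter), close to the scatter. Compound 3 is expected to give about 12 nM in this assay, with a likely range from 3 nM to 50 nM.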

Compound 3, inhibition constant: 3.3 nM
For compound 3 the middle estimate is 3.6-fold (0.56 log units) above the measured one; measured number inside the range.
By their numbers in this assay, from the lowest: compounds 3 and 2 (each within the scatter of the next); then compound 1.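

In this assay the step of a 1.9-fold lower number from compound 2 to compound 3 (0.27 log units; within the scatter) stays within the scatter, so at the end of this chain 2-(methylsulfanyl)phenyl and 4-methoxyphenyl cannot be told apart, even though sulfur enters and oxygen leaves. The step of a 36-fold lower number from compound 1 to compound 3 (1.56 log units; beyond the scatter) is large and shows that the wide gap to compound 1 is not special to 4-methoxyphenyl: among these three compounds, both rings of carbon only give much lower numbers than pyridin-2-yl at this place. Nothing available on these compounds accounts for either result.

The two rings differ in both the atom joined to the ring and the group's printed ring position, and no compound shown separates these two differences, as 4-(methylsulfanyl)phenyl or 2-methoxyphenyl could. Also open, from the compounds shown here alone, is how the number would move with a carbon-only ring carrying an amine or a carboxylic acid at the end of the chain, or with a longer chain leading to the same 2-(methylsulfanyl)phenyl ring.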